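Swapping the carbamate chain end: isobutyl to 2-bromoethyl

A few compounds are considered here, and "the series" means these few. Any claim that something is new, unique, unknown or untested is made for them only; others in the source may bear on it.

Compound 2 `CC(C)COC(=O)N[C@H](C)c1nc2ccc(F)cc2s1` is the more lipophilic of the two measured compounds: in a physicochemical assay for lipophilicity, using the shake flask method, measured as octanol-water partition, with a stated time of 15 min (a lower number here means a more polar compound, a higher number a more lipophilic compound), compound 2 gives 4.24, while compound 1 `COC(=O)N[C@H](C)c1nc2ccc(F)cc2s1` gives 2.5. Within the data shown here, the one measured step, a number 1.74 log units higher from compound 1 to compound 2 (beyond the scatter), shows how strongly this chain end moves the number. Compound 3 `C[C@@H](NC(=O)OCCBr)c1nc2ccc(F)cc2s1` differs from compound 2 by bromomethyl in place of isopropyl on a saturated chain carbon bound to an oxygen next to a carbonyl group. Three carbons leave and a smaller group enters, so a drop is expected, though smaller than that step, since the entering group is not hydrogen; the expected step is a number 0.54 log units lower from compound 2 to compound 3 (beyond the scatter). For compound 3 the estimate is 3.7, between 3.2 and 4.2.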

Compound 3, partition coefficient: 3.17
Compound 3: the middle estimate sits 0.53 log units above what was measured; measured number outside the range, below it.
By their numbers in this assay, from the lowest: compound 1; then compound 3; then compound 2.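

Among these compounds, with a third chain end, this position in this assay no longer offers only two readings. Bromomethyl in place of hydrogen gives a modest rise (a number 0.67 log units higher from compound 1 to compound 3 (beyond the scatter)), while bromomethyl in place of isopropyl gives a large fall (a number 1.07 log units lower from compound 2 to compound 3 (beyond the scatter)), so the 2-bromoethyl end lands in the middle of the three. No outside data explain why the number falls there. Going by these compounds, what a longer chain, an amine or a carboxylic acid would do at this position stays open, as does any other bromine-bearing chain.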